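The source may report more compounds than this note shows. Statements on the series, on what has been measured and on what is new or still open speak of the compounds shown alone.

Measured compounds:
Compound 1 `CCCn1c(=O)c2nc(-c3ccc(S(=O)(=O)NCCCC(=O)OCC)cc3)[nH]c2n(CCC)c1=O` gives 18.5 nM in an assay for binding affinity to adenosine receptor A1 (Rattus norvegicus), read by radioligand binding; on this read-out lower numbers stand for stronger inhibition and higher numbers for weaker inhibition.
Compound 2 `CCCn1c(=O)c2nc(-c3ccccc3N)[nH]c2n(CCC)c1=O` gives 41 nM in this assay.
Compound 3 `CCn1c(=O)c2nc(-c3ccc(S(=O)(=O)N4CCSCC4)cc3)[nH]c2n(CC)c1=O` gives 646 nM in this assay.

Compound 3 stands highest of the three numbers; its nearest neighbour is compound 2 and its furthest is compound 1, and both gaps lie beyond the scatter. Compound 4 `CCn1c(=O)c2nc(-c3ccc(S(=O)(=O)NCCN(C)C)cc3)[nH]c2n(CC)c1=O` shares the core of compound 3 and differs only at the sulfonyl sulfur: (2-(dimethylamino)ethyl)amino in place of thiomorpholin-4-yl on a sulfonyl sulfur. Going by the values given here, no measured pair shows this exact exchange, so the expectation rests on what the three values show. The change from compound 3 to compound 4 is expected to lower the number by a moderate step, a 2.6-fold lower number from compound 3 to compound 4 (0.41 log units; beyond the scatter), probably beyond the scatter. For compound 4 the estimate is 250 nM, within 60 nM to 1000 nM.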

Compound 4, half-maximal inhibitory concentration: 116 nM
For compound 4 the middle estimate is 2.2-fold (0.33 log units) above the measured one, within the range that was stated.
By their numbers in this assay, from the lowest: compound 1; then compound 2; then compound 4; then compound 3.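

At the sulfonyl sulfur, (2-(dimethylamino)ethyl)amino in place of thiomorpholin-4-yl gives, in this assay, a 5.6-fold lower number from compound 3 to compound 4 (0.75 log units; beyond the scatter), so this position can move the number on a shared core. The exchange removes the ring and its sulfur and adds a hydrogen-bond donor, and this single pair cannot separate these changes. Nothing shown accounts for the step. Open, going by these compounds, is whether morpholin-4-yl or a longer chain ending in dimethylamino would give a lower or higher number on this sulfur. Also open, on these data alone, is whether the step would hold on the core of compound 1 .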